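Removing the chloro from the benzamido group of compound 2

A few compounds are considered here, and "the series" means these few. Any claim that something is new, unique, unknown or untested is made for them only; others in the source may bear on it.

Compound 2 `NC(=O)c1c(NC(=O)c2ccccc2Cl)sc2c1CCN(C(=S)Nc1ccccc1)C2` is measured in a functional assay on HeLa cells (Homo sapiens) for antiproliferative activity, with a stated time of 24 h (a lower number here means a stronger inhibitor, a higher number a weaker inhibitor), where compound 2 gives 46700 nM. Compound 3 `NC(=O)c1c(NC(=O)c2ccccc2Cl)sc2c1CCN(C(=S)Nc1ccccc1Br)C2` gives 24600 nM in this assay, and the gap a 1.9-fold lower number from compound 2 to compound 3 (0.28 log units; within the scatter) lies within the scatter, so the two numbers cannot be told apart. Compound 1 `Cc1ccccc1CN1CCc2c(sc(NC(=O)c3ccccc3Cl)c2C(N)=O)C1` returns only a limit in this assay, > 50000 nM, which is the limit of > 50000 nM in this assay, at which 1 of the 3 values shown sits. The steps away from it, an at least 1.0-fold lower number from compound 1 to compound 2 (0.02 log units; that floor lies within the scatter) and an at least 2.0-fold lower number from compound 1 to compound 3 (0.30 log units; that floor lies within the scatter), are floors that also lie within the scatter. Every measured step changes the group on the amine nitrogen in the ring; none of them touches the benzamido group. Compound 4 `NC(=O)c1c(NC(=O)c2ccccc2)sc2c1CCN(C(=S)Nc1ccccc1)C2` differs from compound 2 in that group alone: hydrogen in place of chloro on an aromatic carbon. For the measured compounds named here, no measured step bears on this change, so the account expects no step beyond the scatter, a 1.1-fold higher number from compound 2 to compound 4 (0.03 log units; within the scatter), in this assay. The estimate for compound 4 in this assay is 50000 nM, expected to fall between 20000 nM and 125000 nM.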

Compound 4, half-maximal inhibitory concentration: > 50000 nM
Compound 4: no number, only a limit; the forecaster's own chance of this, stated with the estimate: 45%; the middle value sits exactly at the limit.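

In this assay compound 4 gives only a limit, > 50000 nM. For the compounds shown here, this is the first change to the benzamido group, and hydrogen in place of chloro gives an at least 1.0-fold higher number from compound 2 to compound 4 (0.02 log units; that floor lies within the scatter), so this floor shows no clear effect of removing the chloro, while a larger true step remains possible. Compound 4 joins compound 1 at the limit, leaving fewer exact numbers to compare in this series: the limit of > 50000 nM in this assay, at which 2 of the 4 values shown sit.

The compounds shown leave open whether the chloro matters when the compound keeps a measurable number, as with the bromo group carried by compound 3. They also leave open whether a methoxy group or an amine on that aromatic carbon would give a number clear of the limit.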